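The source may hold more compounds than are shown below. What is called first, only, known or untested is meant among the compounds shown, and "the series" means these compounds.

Compound 1 `CN1CCN(CC(=O)Nc2ccc(-c3nc(-c4ccccc4)c(-c4ccccc4)n3C)cc2)CC1`: 35.5 ug/mL
Compound 2 `Cn1c(-c2ccc(NC(=O)CN3CCN(c4ccccc4)CC3)cc2)nc(-c2ccccc2)c1-c1ccccc1`: 8.6 ug/mL

In a functional assay on HT-29 cells (Homo sapiens) for cytotoxicity, read by MTT assay, with a stated time of 24 h (on this read-out higher numbers stand for weaker inhibition and lower numbers for stronger inhibition), compound 2 gives 8.6 ug/mL, the lowest of the two numbers; compound 1 gives 35.5 ug/mL. For the measured compounds named here, the only measured step, a 4.1-fold lower number from compound 1 to compound 2 (0.62 log units; beyond the scatter), came from putting phenyl in place of methyl on the ring amine nitrogen. Compound 3 `Cn1c(-c2ccc(NC(=O)CN3CCN(Cc4ccccc4)CC3)cc2)nc(-c2ccccc2)c1-c1ccccc1` carries benzyl in place of phenyl on an amine nitrogen in a ring. Going by the values given here, no measured step exchanges phenyl for benzyl, so that step gives only indirect guidance, and a change not beyond the scatter is expected. The step to compound 3 is expected to be a 1.4-fold higher number from compound 2 to compound 3 (0.14 log units; within the scatter). Compound 3 is estimated at 12 ug/mL, between 5 ug/mL and 30 ug/mL.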

Compound 3, half-maximal inhibitory concentration: 65.5 ug/mL
The estimate for compound 3 lay 5.5-fold (0.74 log units) below the measured number; the whole stated range lies below it.
By their numbers in this assay, from the lowest: compound 2; then compounds 1 and 3 (each within the scatter of the next).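

On the amine nitrogen in the ring, the gain seen with phenyl did not carry over to benzyl, although both groups hold one six-membered aromatic ring of carbon only (a 7.6-fold higher number from compound 2 to compound 3 (0.88 log units; beyond the scatter)). Benzyl instead left the number within the scatter of the methyl compound (a 1.8-fold higher number from compound 1 to compound 3 (0.27 log units; within the scatter)), so among these three groups only phenyl stands apart in this assay on this position. No evidence at hand accounts for this difference.

As far as these compounds go, it remains open whether a fluorophenyl, a pyridyl or a phenethyl group on this nitrogen would keep the lower number of compound 2.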